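Toward the free amine again on the shared core

The source may hold more compounds than are shown below. What is called first, only, known or untested is meant among the compounds shown, and "the series" means these compounds.

Among the compounds with values here, compound 2 `Cn1nc2c(=O)n(CC3(O)CCN(Cc4ccc(-c5ccco5)cc4Cl)CC3)cnc2c1-c1ccc(CNC(=O)C(F)(F)F)cc1` gives 2060 nM in an assay on isolated protein for inhibition of ubiquitin carboxyl-terminal hydrolase 7 (Homo sapiens), with stated times of 30 min and 2 h (on this read-out higher numbers stand for weaker inhibition and lower numbers for stronger inhibition), the highest of the three numbers measured so far. Compound 3 `Cn1nc2c(=O)n(CC3(O)CCN(Cc4ccc(-c5ccncc5)cc4Cl)CC3)cnc2c1-c1ccc(CN)cc1` gives 257 nM in this assay, and compound 1 `Cn1nc2c(=O)n(CC3(O)CCN(Cc4ccc(-c5n[nH]c(=O)o5)cc4Cl)CC3)cnc2c1-c1ccc(CN)cc1` gives 171 nM in this assay; both lie well beyond the scatter from compound 2. Within the data shown here, the one measured step that changes a single place, a 1.5-fold higher number from compound 1 to compound 3 (0.18 log units; within the scatter), concerns the aryl group on the other side of the core and not the amine.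

Compound 4 `Cn1nc2c(=O)n(CC3(O)CCN(Cc4ccc(-c5ccco5)cc4Cl)CC3)cnc2c1-c1ccc(CNCCO)cc1` differs from compound 2 by 2-hydroxyethyl in place of (trifluoromethyl)carbonyl on an amine nitrogen. Among the measured compounds shown here, no measured step isolates this change: compound 1 and compound 3 carry the unsubstituted aminomethyl group together with a different aryl group, and compound 2 combines the acylated amine with the furanyl group, so the two differences are never separated. What the numbers show is that the two compounds with a free amine sit far below compound 2, and compound 4 returns a hydrogen-bond donor to that nitrogen.

For the measured compounds named here, compound 4 is therefore expected to give a lower number than compound 2, a step of about a 4.6-fold lower number from compound 2 to compound 4 (0.66 log units; beyond the scatter), with the uncertainty that no single step supports it. The estimated value of compound 4 in this assay is 450 nM, within a range of 150 nM to 1400 nM.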

Compound 4, half-maximal inhibitory concentration: 8.2 nM
Compound 4: the middle estimate sits 55-fold (1.74 log units) above what was measured; measured number below the stated range.
By their numbers in this assay, from the lowest: compound 4; then compounds 1 and 3 (each within the scatter of the next); then compound 2.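

In this assay, within the data shown here, the step of a 250-fold lower number from compound 2 to compound 4 (2.40 log units; beyond the scatter) is the first measured change at this amine nitrogen with the furanyl group held fixed, so the effect of the group on the nitrogen no longer runs together with a change of aryl group. It shows that this position responds strongly to what sits on the nitrogen, and that the nitrogen need not be unsubstituted for a low number, since compound 4, which carries 2-hydroxyethyl there, gives 8.2 nM. Nothing given here accounts for the size of this step.

The compounds shown leave open whether the step reflects the departure of the (trifluoromethyl)carbonyl group or the arrival of the 2-hydroxyethyl group, a question that a simple acetyl or methyl group on the same nitrogen would address. They also leave open how far the hydroxyl end of the chain matters, which a 2-methoxyethyl or 3-hydroxypropyl group would test, and how the unsubstituted aminomethyl group behaves alongside the furanyl group.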